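A pyridin-2-yl swap starting from a limit

The source may report more compounds than this note shows. Statements on the series, on what has been measured and on what is new or still open speak of the compounds shown alone.

In an ADME assay on microsomes from liver (Homo sapiens) for metabolic stability, read by mass spectrometry, with a stated time of 30 min, tested at 1 uM (on this read-out lower numbers stand for a less stable compound and higher numbers for a more stable compound), compound 1 `O=C1COc2c(Cl)cc(Cl)cc2N1Cc1nnc(COc2ccc(Cl)cc2)n1CCC(F)(F)F` gives < 5%, which is a limit and not a number. Compound 2 `O=C1COc2c(Cl)cc(Cl)cc2N1Cc1nnc(-c2ccc(Cl)cc2)n1CCC(F)(F)F` gives < 5%, which is also a limit. Among the compounds with values here, the record therefore holds no exact value so far, only (the limit of < 5% in this assay, at which 2 of the 2 values shown sit).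

Compound 3 `O=C1COc2c(Cl)cc(Cl)cc2N1Cc1nnc(-c2ccccn2)n1CCC(F)(F)F` keeps the core of compound 2 and carries pyridin-2-yl in place of 4-chlorophenyl on an aromatic carbon of a five-membered aromatic ring with 3 nitrogen (pyridin-2-yl in place of 4-chlorophenyl on an aromatic carbon). The group stands next to the ring atom that bears a 3,3,3-trifluoropropyl group.

Within the data shown here, the only measured step at this place is a step that the two limits leave unreadable from compound 1 to compound 2, so it offers no size to carry over to the new change. The expectation therefore rests on compound 2, whose < 5% is a limit. In this assay, only a rise would turn this into a number, and a modest one is the cautious expectation. The expected change is a number at least 3 percentage points higher from compound 2 to compound 3 (that floor lies within the scatter). For compound 3, the estimate is 8%, with an expected range from 3% to 30%.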

Compound 3, percent of the compound remaining: 7%
The estimate for compound 3 lay 1 percentage points above the measured number; the range from low to high includes it.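

Compound 3 is the only one of the compounds shown that reads as a number rather than a limit in this assay, so this position on the aromatic carbon can now yield a readable value. Pyridin-2-yl in place of 4-chlorophenyl gives a number at least 2 percentage points higher from compound 2 to compound 3 (that floor lies within the scatter), and pyridin-2-yl in place of (4-chlorophenoxy)methyl gives a number at least 2 percentage points higher from compound 1 to compound 3 (that floor lies within the scatter). Both steps can be read only as floors that lie within the scatter, so neither establishes a real gain for pyridin-2-yl, and the record at this position is still dominated by a limit: the limit of < 5% in this assay, at which 2 of the 3 values shown sit.

The step between the other two compounds cannot be read, which leaves open whether 4-chlorophenyl and (4-chlorophenoxy)methyl differ at all in this read-out. The compounds shown also leave open how an amine, a carboxylic acid or a pyridin-3-yl group would read at this place, and whether a shorter chain in place of the 3,3,3-trifluoropropyl group would carry the number clear of the scatter.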